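This account rests on a few compounds, and the source may have more. Where it says the series, first, only, none or still open, it means among the compounds named here.

Measured so far:
compound 1 `Cc1cc(Nc2ncc(Cl)c(Nc3cn(C)nc3S(=O)(=O)C(C)C)n2)c(OC(C)C)cc1C1CCNC1` — 28 nM
compound 2 `Cc1cc(Nc2ncc(Cl)c(Nc3cn(C)nc3S(=O)(=O)C(C)C)n2)c(C(F)(F)F)cc1C1CCN(C)CC1` — 74 nM

In a functional assay on KARPAS-299 cells (Homo sapiens) for inhibition, read by CellTiter-Glo, with a stated time of 96 h (on this read-out lower numbers stand for stronger inhibition and higher numbers for weaker inhibition), compound 1 gives 28 nM, the lowest of the two numbers. Compound 2 gives 74 nM in this assay, a higher number whose gap to compound 1 lies beyond the usual scatter; the two compounds differ in more than one place, so the two values only show that compound 1 is the stronger of the pair.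

Compound 3 `Cc1cc(Nc2ncc(Cl)c(Nc3cn(C)nc3S(=O)(=O)C(C)C)n2)c(OC(C)C)cc1C1CCN(C)C1` has not been measured. It differs from compound 1 in one place: methyl in place of hydrogen on an amine nitrogen in a ring. Within the data shown here, no pair of measured compounds that differ in one place is available, so nothing here shows how this change has behaved before. The expectation is a step in this assay of no clear size beyond the scatter, in either direction. Compound 3 is therefore estimated at 30 nM, within 12 nM to 80 nM, an expected step of a 1.1-fold higher number from compound 1 to compound 3 (0.03 log units; within the scatter).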

Compound 3, half-maximal inhibitory concentration: 11 nM
Estimate against measurement, compound 3: 2.7-fold (0.44 log units) above, outside the stated range (below it).
By their numbers in this assay, from the lowest: compound 3; then compound 1; then compound 2.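

In this assay, among these compounds, the change from pyrrolidin-3-yl to 1-methylpyrrolidin-3-yl gives a 2.5-fold lower number from compound 1 to compound 3 (0.41 log units; beyond the scatter) and this modest step is the first reading of a single change. It shows that this amine nitrogen in the ring can carry a methyl in place of hydrogen without losing inhibition, and that here the number moves towards stronger inhibition, though this rests on one pair of compounds alone. Nothing at hand accounts for this step.

From the compounds shown here alone, what remains open is whether a longer chain such as ethyl or propyl, or an acetyl group, on the same nitrogen would lower the number further, leave it unchanged or raise it. One pair also cannot show whether the methyl would give a similar step on a compound that differs elsewhere from compound 1.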